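Dimethoxyphenyl in Place of Methylphenyl on a Triazole Nitrogen

A few compounds are considered here, and "the series" means these few. Any claim that something is new, unique, unknown or untested is made for them only; others in the source may bear on it.

Measured so far:
compound 1 `CC(=O)Nc1ccc(-n2nncc2CN2C(=O)C3(C(C#N)=C(N)Oc4c3c3nc5ccccc5nc3c3ccccc43)c3ccccc32)cc1`: > 50000 nM
compound 2 `Cc1ccccc1-n1nncc1CN1C(=O)C2(C(C#N)=C(N)Oc3c(N)cc4nc5ccccc5nc4c32)c2ccccc21`: > 50000 nM

In an ADME assay on HUVEC cells (Homo sapiens) for antiproliferative activity, read by MTT assay, with a stated time of 48 h (a higher number here means a weaker inhibitor, a lower number a stronger inhibitor), compound 1 gives > 50000 nM, which is a limit of the assay and not a number. Compound 2 gives > 50000 nM, again a limit rather than a number. Compound 2 thus stands at the limit of > 50000 nM in this assay, at which 2 of the 2 values shown sit, together with compound 1, and the two values do not separate the compounds. Among the compounds with values here, no step between measured compounds is available, so nothing is known about how any change in the shared core moves the readout.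

Compound 3 `COc1ccc(OC)c(-n2nncc2CN2C(=O)C3(C(C#N)=C(N)Oc4c(N)cc5nc6ccccc6nc5c43)c3ccccc32)c1` differs from compound 2 in one place: 2,5-dimethoxyphenyl in place of 2-methylphenyl on an aromatic nitrogen. Since both known values sit at the limit, the step implied by the estimate, a step that the limit leaves unreadable from compound 2 to compound 3, is expected to be none beyond the scatter. Compound 3 is accordingly expected to come out near 60000 nM, within 25000 nM to 200000 nM, and most probably again only as a limit.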

Compound 3, half-maximal inhibitory concentration: > 50000 nM
Compound 3: a limit, no number (the forecaster's own chance of this, stated with the estimate: 85%); the middle value does not contradict the limit.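

In this assay compound 3 gives > 50000 nM, a limit of the assay and not a number. No step from compound 2 to compound 3 can be read, and all the values shown coincide: the limit of > 50000 nM in this assay, at which 3 of the 3 values shown sit.

Whether 2,5-dimethoxyphenyl in place of 2-methylphenyl, or any other change among these compounds, moves the read-out at all stays open.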